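The source may hold more compounds than are shown below. What is called first, only, known or untested is meant among the compounds shown, and "the series" means these compounds.

Working notes on a hydroxamic acid series read in an assay on Sf9 cells for inhibition of protein deacetylase HDAC6 (Homo sapiens), read by fluorescence, with a stated time of 40 min, tested at 100 nM; a lower number here means less inhibition, a higher number more inhibition at the concentration tested (going by the name of the read-out). Three analogues carry different aryl groups on the same carbon of the shared core. Compound 1 `O=C(NO)c1ccc(NCc2nc(-c3cccnc3)nn2-c2ccccc2)cc1` gives 57.7%. Compound 2 `Cc1ccccc1-c1nc(CNc2ccc(C(=O)NO)cc2)n(-c2ccccc2)n1` gives 53.2%, and compound 3 `O=C(NO)c1ccc(NCc2nc(-c3ccc(Br)o3)nn2-c2ccccc2)cc1` gives 55.8%. The three numbers sit close together: the step of a number 4.5 percentage points lower from compound 1 to compound 2 (within the scatter), the step of a number 1.9 percentage points lower from compound 1 to compound 3 (within the scatter) and the step of a number 2.6 percentage points higher from compound 2 to compound 3 (within the scatter) are each within the scatter, so no order among compounds 1, 2 and 3 can be read from them. Compound 3 is the second highest of the three numbers, nearest to compound 1 and furthest from compound 2, both gaps inside the scatter.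

The next analogue is compound 4 `O=C(NO)c1ccc(NCc2nc(-c3ccncc3)nn2-c2ccccc2)cc1`. Relative to compound 3 the change is pyridin-4-yl in place of 5-bromofuran-2-yl on an aromatic carbon. Going by the values given here, the steps that bear on this are those already seen at the same aromatic carbon, a number 1.9 percentage points lower from compound 1 to compound 3 (within the scatter) and a number 2.6 percentage points higher from compound 2 to compound 3 (within the scatter), where exchanging one aryl group for another moved the inhibition by amounts within the scatter. A pyridin-4-yl entering in place of 5-bromofuran-2-yl is therefore expected to give no step beyond the scatter in this assay. The estimated step is a number 0.2 percentage points higher from compound 3 to compound 4 (within the scatter). For compound 4 the expected inhibition is 56%, with an expected range from 44% to 68%.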

Compound 4, a percentage reported as inhibition, at one concentration (the size of the read-out at that concentration, not a potency): 30.8%
Beside the measured number, compound 4's estimate is 25.2 percentage points above it; measured number outside the range, below it.
By their numbers in this assay, from the lowest: compound 4; then compounds 2, 3 and 1 (each within the scatter of the next).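

At this aromatic carbon, between two ring nitrogen atoms, the aryl groups are no longer interchangeable in this assay, since a number 25 percentage points lower from compound 3 to compound 4 (beyond the scatter) and a number 22.4 percentage points lower from compound 2 to compound 4 (beyond the scatter), while every exchange among compounds 1, 2 and 3 stayed within the scatter. The most telling comparison is between the two pyridines, with a number 26.9 percentage points lower from compound 1 to compound 4 (beyond the scatter) on replacing pyridin-3-yl with pyridin-4-yl, so a pyridine ring alone does not account for the lower number, and compound 1 goes against any such reading. Nothing available explains why pyridin-4-yl stands apart from the other three aryl groups at this position.

As far as these compounds go, it remains open whether pyridin-2-yl, an unsubstituted phenyl or a phenyl carrying an amine or a carboxylic acid on this carbon would group with compounds 1, 2 and 3 or with compound 4. Because each compound is represented by a single inhibition reading at one concentration, these numbers also leave open how far the step from the other three compounds to compound 4 reflects a difference in potency.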